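The source may hold more compounds than are shown below. What is called first, only, known or untested is meant among the compounds shown, and "the series" means these compounds.

Within the data shown here, compound 1, `COc1cccc(/C=C/C(=O)c2c(OC)cc(OC)cc2OC)c1`, is one of two compounds measured in a functional assay on HaCaT cells (Homo sapiens), read by fluorescence and BrdU incorporation, with a stated time of 48 h, tested at 10 uM; on this read-out lower numbers stand for a stronger effect and higher numbers for a weaker effect at the one concentration tested. Compound 1 gives 19%, the lower of the two numbers. Compound 2, `COc1cc(O)c(C(=O)/C=C/c2ccccc2OC)c(OC)c1`, gives 49% in this assay, a number that stands beyond the usual scatter above compound 1, so compound 1 shows the stronger effect of the two.

Compound 3, `COc1cc(OC)c(C(=O)/C=C/c2ccc(F)cc2)c(OC)c1`, differs from compound 1 in one place: 4-fluorophenyl in place of 3-methoxyphenyl on a double-bonded chain carbon bound to a double-bonded chain carbon. Among the measured compounds shown here, no pair of measured compounds shows this change, so nothing measured tells how large a step to expect. Given that compound 1 already stands at 19%, compound 3 is expected to stay near that mark, with at most a small step toward a weaker effect in this assay, a number 9 percentage points higher from compound 1 to compound 3 (within the scatter), which may well lie within the scatter. Compound 3 is therefore estimated at 28%, within a range from 12% to 52%.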

Compound 3, a percentage reported as activity, at one concentration (the size of the read-out at that concentration, not a potency): 20%
For compound 3 the middle estimate is 8 percentage points above the measured one; the measured number falls inside the stated range.
By their numbers in this assay, from the lowest: compounds 1 and 3 (each within the scatter of the next); then compound 2.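

In this assay, among these compounds, 4-fluorophenyl in place of 3-methoxyphenyl on a double-bonded chain carbon bound to a double-bonded chain carbon gives a number 1 percentage points higher from compound 1 to compound 3 (within the scatter) and so shows that this position accepts the exchange with no step that can be told from the scatter. The exchange removes the one hydrogen-bond acceptor counted in the leaving group, yet at the one concentration tested the read-out does not separate the two groups. Nothing available explains why the two compounds read alike.

The compounds shown leave open whether a phenyl carrying an amine or a carboxylic acid at this place would also stay within the scatter of compound 1. They also leave open whether the same exchange would read alike on the core of compound 2.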